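Stereochemical inversion in a pyrrolidine hydroxamate series

The source may hold more compounds than are shown below. What is called first, only, known or untested is meant among the compounds shown, and "the series" means these compounds.

Compound 3 `O=C(NO)[C@H]1C[C@@H](NS(=O)(=O)c2ccc(-c3ccccc3)cc2)CN1S(=O)(=O)c1ccc(Cl)c(Cl)c1` gives 100% in an assay on isolated protein for inhibition of matrix metalloproteinase-9 (Homo sapiens), read by fluorescence, with stated times of 5 min and 30 min, tested at 5 uM (on this read-out lower numbers stand for less inhibition and higher numbers for more inhibition at the one concentration tested (going by the name of the read-out)), and stands at the top of the two numbers recorded, with compound 1 `O=C(N[C@@H]1C[C@H](C(=O)NO)N(S(=O)(=O)c2ccc(Cl)c(Cl)c2)C1)c1cccs1` nearest at 95%, a gap within the scatter. Compound 2 `O=C(N[C@H]1C[C@H](C(=O)NO)N(S(=O)(=O)c2ccc(Cl)c(Cl)c2)C1)c1cccs1` is reported in this assay as "not active" (no number reported). The relevance of configuration is shown by the fact that compounds 1 and 2 differ only in the configuration as drawn. Compound 4 `O=C(NO)[C@H]1C[C@H](NS(=O)(=O)c2ccc(-c3ccccc3)cc2)CN1S(=O)(=O)c1ccc(Cl)c(Cl)c1` is the next step from compound 3: the two compounds have the same atoms and bonds and differ only in configuration as drawn: 1 of 2 stereo elements differ; a stereocentre at a saturated ring carbon is drawn R in compound 3 and S in compound 4. Among the compounds with values here, no measured step covers this exact change, so the size of the change in this assay is judged from compounds 1 and 2: a large loss of inhibition is expected, possibly to the point where only a limit is reported. For compound 4 the estimate in this assay is 15%, between 0% and 55%, meaning an expected step of a number 85 percentage points lower from compound 3 to compound 4 (beyond the scatter).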

Compound 4, a percentage reported as inhibition, at one concentration (the size of the read-out at that concentration, not a potency): 100%
For compound 4 the middle estimate is 85 percentage points below the measured one; measured number outside the range, above it.
By their numbers in this assay, from the lowest: compounds 1, 3 and 4 (each within the scatter of the next).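

Inversion at this saturated ring carbon gives no change at the digits printed from compound 3 to compound 4 (within the scatter) in this assay. The earlier pair suggested a strong dependence on configuration, with compound 1 at 95% and compound 2 at "not active" (no number reported), but that dependence does not carry over to the sulfonamide pair, so it is not a general feature of this stereocentre.

A read-out at one concentration cannot show whether compounds 3 and 4 differ in potency. Also open, from the compounds shown here alone, is whether configuration matters when this ring carbon carries an amine or a carboxylic acid.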